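The source may hold more compounds than are shown below. What is called first, only, known or untested is meant among the compounds shown, and "the series" means these compounds.

Compound 1 (`CCOC(=O)CCN1CCN(c2c(F)cc3c(=O)c(C(=O)O)cn(C4CC4)c3c2OC)CC1C`) gives ("not determined" (no result reported))
Compound 2 (`COc1c(N2CCN(CC(C)=O)C(C)C2)c(F)cc2c(=O)c(C(=O)O)cn(C3CC3)c12`) gives (500 ug/mL)

For the measured compounds named here, in an ADME assay on Vero cells (Chlorocebus sabaeus) for cytotoxicity, read by MTT assay, with a stated time of 72 h (on this read-out lower numbers stand for higher toxicity in this test and higher numbers for lower toxicity in this test), compound 2 gives 500 ug/mL as the only number so far. Compound 1 has no reported result, so compound 2 cannot yet be placed high or low within the series.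

Compound 3 (`CO/N=C(\C)CN1CCN(c2c(F)cc3c(=O)c(C(=O)O)cn(C4CC4)c3c2OC)CC1C`) has still to be measured. It differs from compound 2 by one change (a group of 5 heavy atoms (3 carbon, 1 nitrogen, 1 oxygen; no ring) in place of a group of 3 heavy atoms (2 carbon, 1 oxygen; no ring), on a saturated chain carbon bound to an amine nitrogen in a ring), and the rest of the structure stays the same. Going by the values given here, no pair of measured compounds shows what a change of this kind does in this assay, so the data offer no direction for it. A step no larger than the usual scatter is expected, and the estimated step (a 1.3-fold lower number from compound 2 to compound 3 (0.10 log units; within the scatter)) should be read that way. For compound 3 the estimated value is 400 ug/mL within an expected range of 150 ug/mL to 900 ug/mL in this read-out.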

Compound 3, half-maximal cytotoxic concentration: 49.6 ug/mL
Beside the measured number, compound 3's estimate is 8.1-fold (0.91 log units) above it; the measured number lies below the stated range.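

In this assay the exchange of acetyl for the group of 5 heavy atoms gives a 10-fold lower number from compound 2 to compound 3 (1.00 log units; beyond the scatter) and puts compound 3 on the more toxic side of compound 2. The position, on a saturated chain carbon bound to an amine nitrogen in a ring, therefore responds to the group it carries, which a single number could not show, although one pair sets no trend. No measurement at hand accounts for this step.

On these data alone, whether the step follows the oxygen and nitrogen of the entering group or the group as a whole remains open. As far as these compounds go, it is also open how an amine, a carboxylic acid or a longer chain would read at this position, and one pair gives no direction for any of them.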